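Changing the Chain End of Compound 3

The source may report more compounds than this note shows. Statements on the series, on what has been measured and on what is new or still open speak of the compounds shown alone.

- Compound 1 `N=c1sc2cc(OC(F)(F)F)ccc2n1CCS(=O)(=O)O`: > 10 mg/kg, a limit of the assay
- Compound 2 `N=c1sc2cc(OC(F)(F)F)ccc2n1CCO`: 8 mg/kg
- Compound 3 `N=c1sc2cc(OC(F)(F)F)ccc2n1CCS`: 2 mg/kg

In a functional assay on the whole organism with Rattus norvegicus as the target (on this read-out higher numbers stand for an effect only at larger amounts of compound and lower numbers for an effect already at smaller amounts), compound 3 holds the lowest number at 2 mg/kg. Compound 4 `C[S+]([O-])CCCn1c(=N)sc2cc(OC(F)(F)F)ccc21` differs from it by a group of 4 heavy atoms (2 carbon, 1 oxygen, 1 sulfur; no ring) in place of one sulfur atom, on a saturated chain carbon, two bonds along the chain from an aromatic nitrogen. All three measured steps were made at this same place. The two that reach compound 3 are a 4.0-fold lower number from compound 2 to compound 3 (0.60 log units; beyond the scatter) and an at least 5.0-fold lower number from compound 1 to compound 3 (0.69 log units; beyond the scatter). The third, an at least 1.2-fold lower number from compound 1 to compound 2 (0.09 log units; that floor lies within the scatter), does not separate the other two compounds. Neither of the groups replacing sulfanyl in these steps resembles the entering one, but both gave higher numbers, as a 4.0-fold lower number from compound 2 to compound 3 (0.60 log units; beyond the scatter) shows for hydroxy. A modest step to a higher number is therefore expected, and the expected change is a 2.5-fold higher number from compound 3 to compound 4 (0.40 log units; beyond the scatter). The estimated value for compound 4 is 5 mg/kg, with an expected range of 1.5 mg/kg to 15 mg/kg.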

Compound 4, dose for half-maximal effect: 2.3 mg/kg
Estimate against measurement, compound 4: 2.2-fold (0.34 log units) above, within the range that was stated.
By their numbers in this assay, from the lowest: compounds 3 and 4 (each within the scatter of the next); then compound 2. At a limit, above all of these: compound 1.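

In this assay, the larger group entering at this position, which counts no hydrogen-bond donor, gives a 1.2-fold higher number from compound 3 to compound 4 (0.06 log units; within the scatter), so compound 3 and compound 4 cannot be told apart. The gap to the other chain ends remains, with a 3.5-fold lower number from compound 2 to compound 4 (0.54 log units; beyond the scatter) and an at least 4.3-fold lower number from compound 1 to compound 4 (0.63 log units; beyond the scatter). The last of these steps rests on the limit of compound 1: the limit of > 10 mg/kg in this assay, at which 1 of the 4 values shown sits.

From the compounds shown here alone, how an amine or a carboxylic acid on this chain carbon would read remains open. So does whether a longer chain would keep the number of compound 4.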